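The compounds below may be only part of what the source reports. "The series", "measured", "known", "first", "only" and "open" are said of these compounds alone.

Measured compounds:
compound 1 `N#Cc1cc2c(nc1N1CCC(C(=O)NS(=O)(=O)C(F)(F)c3ccccc3)CC1)COC2=O` — "not determined" (no result reported) in a functional assay (Platelet, plasma) for inhibition, with Homo sapiens as the target; on this read-out higher numbers stand for weaker inhibition and lower numbers for stronger inhibition
compound 2 `CC(c1ccccc1)S(=O)(=O)NC(=O)C1CCN(c2nc3c(cc2C#N)C(=O)OC3)CC1` — 4160 nM
compound 3 `N#Cc1ccc(CS(=O)(=O)NC(=O)C2CCN(c3nc4c(cc3C#N)C(=O)OC4)CC2)cc1` — 8900 nM

Compound 3 holds the highest of the two numbers in this assay; its nearest neighbour is compound 2, and the step of a 2.1-fold higher number from compound 2 to compound 3 (0.33 log units; beyond the scatter) lies beyond the scatter. Among the compounds with values here, compound 1 carries no result in this assay, so only two numbers anchor the series.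

Compound 4 `N#Cc1cc2c(nc1N1CCC(C(=O)NS(=O)(=O)Cc3cccc(F)c3)CC1)COC2=O` differs from compound 3 in one place: 3-fluorophenyl in place of 4-cyanophenyl on a saturated chain carbon bound to a sulfonyl sulfur. Within the data shown here, no measured pair exchanges one substituted phenyl for another on a saturated chain carbon bound to a sulfonyl sulfur. Among the measured compounds shown here, the only measured step, a 2.1-fold higher number from compound 2 to compound 3 (0.33 log units; beyond the scatter), replaces 1-phenylethyl with 4-cyanobenzyl and is modest in size; it shows that changes at this part of the molecule move this assay only by small amounts among the compounds seen. The change to compound 4 retains a benzyl-type group and is therefore expected to produce a step of comparable size or smaller, most likely toward a lower number, though possibly within the scatter.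

Compound 4 is expected to give 6000 nM in this assay, within a range from 2500 nM to 15000 nM. That corresponds to an expected step of a 1.5-fold lower number from compound 3 to compound 4 (0.17 log units; within the scatter).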

Compound 4, half-maximal inhibitory concentration: 70500 nM
Beside the measured number, compound 4's estimate is 12-fold (1.07 log units) below it; measured number above the stated range.
By their numbers in this assay, from the lowest: compound 2; then compound 3; then compound 4.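

In this assay, within the data shown here, the aryl group on a saturated chain carbon bound to a sulfonyl sulfur matters more than the earlier pair suggested: 3-fluorophenyl in place of 4-cyanophenyl gives a 7.9-fold higher number from compound 3 to compound 4 (0.90 log units; beyond the scatter), whereas the only earlier change gave a 2.1-fold higher number from compound 2 to compound 3 (0.33 log units; beyond the scatter). Retaining the benzyl type therefore does not keep the number stable, and the exchange of 1-phenylethyl for 3-fluorobenzyl gives a 17-fold higher number from compound 2 to compound 4 (1.23 log units; beyond the scatter), which widens the span at this position and leaves compound 2 lowest and compound 4 highest of the three numbers. No independent measurement on these compounds bears on the size of these steps.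

The change from 4-cyanobenzyl to 3-fluorobenzyl alters both the substituent and the number in the group's name, so the compounds shown cannot separate the loss of the nitrile from the shift in where the substituent sits. Also open, as far as these compounds go, is whether unsubstituted benzyl, or a phenyl ring carrying a carboxylic acid or an amine, on the same saturated chain carbon would fall nearer compound 2 or compound 4.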